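A ring swap on compound 3 at the assay limit

A few compounds are considered here, and "the series" means these few. Any claim that something is new, unique, unknown or untested is made for them only; others in the source may bear on it.

Of the compounds shown here, three have been measured in a functional assay on A-375 cells (Homo sapiens) for antiproliferative activity; on this read-out lower numbers stand for stronger inhibition and higher numbers for weaker inhibition. Compound 1 `O=C(Nc1ccc(-c2cscn2)cc1)C1CN(Cc2ccc(F)c(F)c2)C1` gives > 20000 nM, which is a limit of the assay and not a number. Compound 2 `O=C(Nc1ccc(-c2cscn2)cc1)C1CCCN(Cc2cccc(OC(F)(F)F)c2)C1` gives > 20000 nM, again a limit. Compound 3 `O=C(Nc1ccc(-c2c[nH]cn2)cc1)C1CCCN(Cc2ccc(F)c(F)c2)C1` gives > 20000 nM, also a limit. Compound 3 therefore has no exact value and shares its place with the other two: the limit of > 20000 nM in this assay, at which 3 of the 3 values shown sit.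

Compound 4 `O=C(Nc1ccc(-c2ccc[nH]2)cc1)C1CCCN(Cc2ccc(F)c(F)c2)C1` differs from compound 3 in one place: 1H-pyrrol-2-yl in place of 1H-imidazol-4-yl on an aromatic carbon. The new ring, 1H-pyrrol-2-yl, sits on an aromatic carbon, para to a large group. Among the compounds with values here, no measured pair shows what this swap does in this assay, so the expectation rests on compound 3, whose > 20000 nM is a limit. The expected result is a number no higher from compound 3 to compound 4 (the limit leaves the size open), meaning no change beyond the usual scatter in either direction. For compound 4 the estimated value is 20000 nM, with an expected range from 8000 nM to 30000 nM.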

Compound 4, half-maximal inhibitory concentration: 360 nM
Estimate against measurement, compound 4: 56-fold (1.74 log units) above; the whole stated range lies above it.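

In this assay, the ring at this place, on an aromatic carbon para to a large group, proves decisive: 1H-pyrrol-2-yl in place of 1H-imidazol-4-yl gives an at least 55-fold lower number from compound 3 to compound 4 (1.74 log units; beyond the scatter). The two rings have the same size and the same count of hydrogen-bond donors, while the entering ring has one hetero atom fewer and no hydrogen-bond acceptor, so a small change in the ring is enough to separate the two compounds. Compound 4 also gives the only exact number so far, and the other compounds remain at a limit: the limit of > 20000 nM in this assay, at which 3 of the 4 values shown sit.

From the compounds shown here alone, what remains open is which feature of the ring matters, since a single pair cannot separate the lost ring nitrogen from other differences. A phenyl ring, a furan-2-yl ring or a methyl group on the pyrrole nitrogen at this place would help to separate them, and the effect of 1H-pyrrol-2-yl alongside the other side chains of compound 1 and compound 2 is also unknown.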